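Swapping Nitro for Fluoro on a Shared Core

This account rests on a few compounds, and the source may have more. Where it says the series, first, only, none or still open, it means among the compounds named here.

Of the compounds shown here, two have been measured in a functional assay on A549 cells (Homo sapiens) for antiproliferative activity, read by MTT assay, with a stated time of 48 h; on this read-out lower numbers stand for stronger inhibition and higher numbers for weaker inhibition. Compound 1 `Cc1cc(Nc2nc(Nc3ccc(C(=O)NC4CC(C)(C)N([O])C(C)(C)C4)cc3)ncc2[N+](=O)[O-])no1` gives 1140 nM and stands highest of the two numbers, with compound 2 `CCOC(=O)Cc1csc(Nc2nc(Nc3ccc(C(=O)NC4CC(C)(C)N([O])C(C)(C)C4)cc3)ncc2[N+](=O)[O-])n1` as its nearest neighbour at 1040 nM. Among the measured compounds shown here, the single measured step, a 1.1-fold lower number from compound 1 to compound 2 (0.04 log units; within the scatter), exchanges the group on a nitrogen on an aromatic ring and leaves the nitro group untouched.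

Compound 3 `Cc1cc(Nc2nc(Nc3ccc(C(=O)NC4CC(C)(C)N([O])C(C)(C)C4)cc3)ncc2F)no1` is the unmeasured partner of compound 1. The change is fluoro in place of nitro on an aromatic carbon of a six-membered aromatic ring with two nitrogens, ortho to the (5-methyl-1,2-oxazol-3-yl)amino group and para to a large group.

For the measured compounds named here, no measured step touches this position, so the step from compound 1 to compound 2 is no direct guide; it shows only that the shared core tolerates a change elsewhere without a shift beyond the scatter. With nothing measured on the nitro itself, neither direction can be excluded, and the expected step of a 1.3-fold higher number from compound 1 to compound 3 (0.12 log units; within the scatter) is set near no change but with a wide range. Compound 3 is therefore expected to give about 1500 nM in this assay, between 400 nM and 6000 nM.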

Compound 3, half-maximal inhibitory concentration: 880 nM
Compound 3: the middle estimate sits 1.7-fold (0.23 log units) above what was measured; measured number inside the range.
By their numbers in this assay, from the lowest: compounds 3, 2 and 1 (each within the scatter of the next).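

In this assay, among the compounds shown here, this is the first look at the position itself: fluoro in place of nitro on an aromatic carbon gives a 1.3-fold lower number from compound 1 to compound 3 (0.11 log units; within the scatter). The nitro group, with 3 heavy atoms and 2 hydrogen-bond acceptors, can therefore give way to fluoro, with 1 heavy atom and no hydrogen-bond acceptors, without a shift beyond the scatter, so on this core the antiproliferative read-out does not depend on the nitro group being present. No supporting measurement is available to explain why the two groups read alike here, and a similar number does not by itself show that the compounds act in the same way.

As far as these compounds go, the pair shows this exchange only alongside the 5-methyl-1,2-oxazol-3-yl group, so it remains open whether fluoro in place of nitro would read the same on compound 2, which carries 4-((ethoxycarbonyl)methyl)-1,3-thiazol-2-yl instead. From the compounds shown here alone, it is also open whether a plain hydrogen, an amine, a nitrile or a methyl group on the same aromatic carbon would stay within the scatter of these numbers or move clearly away from them.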